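Cytotoxicity on Vero cells: a chloro for methyl swap

The compounds below may be only part of what the source reports. "The series", "measured", "known", "first", "only" and "open" are said of these compounds alone.

Measured compounds:
compound 1 `CCOC(=O)C1=C(C)N(c2cccc(C)c2)C(C)=C(C(=O)OCC)C1c1cn(-c2ccccc2)nc1-c1ccccc1` — > 10 ug/mL
compound 2 `CCOC(=O)C1=C(C)N(c2ccc(C)cc2)C(C)=C(C(=O)OCC)C1c1cn(-c2ccccc2)nc1-c1ccccc1` — "not determined" (no result reported)

Compound 1 `CCOC(=O)C1=C(C)N(c2cccc(C)c2)C(C)=C(C(=O)OCC)C1c1cn(-c2ccccc2)nc1-c1ccccc1` was tested in an ADME assay on Vero cells (Chlorocebus sabaeus) for cytotoxicity; on this read-out higher numbers stand for weaker inhibition and lower numbers for stronger inhibition; for compound 1 the result is a limit, > 10 ug/mL. Compound 2 `CCOC(=O)C1=C(C)N(c2ccc(C)cc2)C(C)=C(C(=O)OCC)C1c1cn(-c2ccccc2)nc1-c1ccccc1` has no number at all in this assay, where compound 2 is reported as "not determined" (no result reported). Of the two values given, one sits at the limit of > 10 ug/mL in this assay, at which 1 of the 2 values shown sits. Compound 2 therefore stands nowhere on a scale; only the limit of compound 1 tells where this series tends to sit.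

Compound 3 `CCOC(=O)C1=C(C)N(c2cccc(Cl)c2)C(C)=C(C(=O)OCC)C1c1cn(-c2ccccc2)nc1-c1ccccc1` is the next member: 3-chlorophenyl in place of 4-methylphenyl on an amine nitrogen in a ring. Going by the values given here, no step between measured compounds exists for comparison, so the change from compound 2 to compound 3 in this assay cannot be sized from the data; no shift beyond the usual scatter is expected, and the direction is open. On the limit shown for compound 1, compound 3 is expected to give about 15 ug/mL in this assay, within 5 ug/mL to 60 ug/mL, most likely again reported only as a limit.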

Compound 3, half-maximal inhibitory concentration: 7.08 ug/mL
The estimate for compound 3 lay 2.1-fold (0.33 log units) above the measured number; measured number inside the range.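

In this assay, compound 3 gives this series its first actual number, so a change in the aryl group on the amine nitrogen in a ring can now be read against a measured value and not only against a limit. Chloro in place of methyl on an aromatic carbon amounts to an at least 1.4-fold lower number from compound 1 to compound 3 (0.14 log units; that floor lies within the scatter), so the true gap could be larger, but what can be read does not establish a shift beyond the usual scatter. The value for compound 1 remains a limit and not a number: the limit of > 10 ug/mL in this assay, at which 1 of the 3 values shown sits.

Any step involving compound 2 cannot be read, so the effect of moving a group around the phenyl ring stays unknown. Also open, from the compounds shown here alone, is how a methoxy group or an amine on that phenyl ring would read in this assay.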